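The compounds below may be only part of what the source reports. "The series", "measured", "known", "first", "only" and "open" are said of these compounds alone.

Compound 3 `N#Cc1c(N2CCC(c3ccccc3)CC2)ccn(CCC2CC2)c1=O` stands highest of the three numbers in a functional assay on CHO cells for positive allosteric modulation of metabotropic glutamate receptor 2 (Homo sapiens), with a stated time of 30 min; on this read-out lower numbers stand for smaller maximal responses and higher numbers for larger maximal responses: compound 3 gives 316%, while compound 1 `CCCCn1ccc(N2CCC(c3ccccc3)CC2)c(C#N)c1=O` gives 309% and compound 2 `N#Cc1c(N2CCC(c3ccccc3)CC2)ccn(CC2CCC2)c1=O` gives 269%. One gap is a number 7 percentage points higher from compound 1 to compound 3 (within the scatter), within the scatter, so those two cannot be ordered; the other gap is a number 47 percentage points higher from compound 2 to compound 3 (beyond the scatter), beyond it.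

Compound 4 `N#Cc1c(N2CCC(c3ccccc3)CC2)ccn(CCCC(F)(F)F)c1=O` differs from compound 3 by 2,2,2-trifluoroethyl in place of cyclopropyl on a saturated chain carbon, two bonds along the chain from an aromatic nitrogen. Of the measured steps, a number 7 percentage points higher from compound 1 to compound 3 (within the scatter) is the one made at the same place, a change of the chain end two bonds along from the aromatic nitrogen, and it stayed within the scatter. The two larger steps, a number 40 percentage points lower from compound 1 to compound 2 (beyond the scatter) and a number 47 percentage points higher from compound 2 to compound 3 (beyond the scatter), concern the saturated chain carbon bound to the aromatic nitrogen, which is left unchanged here. The expectation for compound 4 in this assay is accordingly a step of a number 11 percentage points lower from compound 3 to compound 4 (beyond the scatter), not beyond the scatter. Compound 4 is estimated at 305%, with a range from 255% to 355%.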

Compound 4, largest response reached (Emax), in percent of the reference or control that the assay uses: 302%
Compound 4: the middle estimate sits 3 percentage points above what was measured; low and high end bracket the measured number.
By their numbers in this assay, from the lowest: compound 2; then compounds 4, 1 and 3 (each within the scatter of the next, the first and the last beyond it).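

In this assay, trifluoromethyl in place of methyl, three bonds along the chain from an aromatic nitrogen, gives a number 7 percentage points lower from compound 1 to compound 4 (within the scatter), so compound 1 and compound 4 cannot be ordered and this fluorinated chain end holds the large maximal response of the plain chain. The chain end can still separate compounds: 2,2,2-trifluoroethyl in place of cyclopropyl gives a number 14 percentage points lower from compound 3 to compound 4 (beyond the scatter), a modest step and the first beyond the scatter at this place, although compound 1 lies within the scatter of both. 3,3,3-trifluoropropyl in place of cyclobutyl gives a number 33 percentage points higher from compound 2 to compound 4 (beyond the scatter), which leaves compound 2 the lowest of the four.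

Going by these compounds, whether a chain end bearing an amine, a carboxylic acid or a methoxy group keeps this response remains open. No available evidence explains these steps.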